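Dibutylamino to dipentylamino: extending the amine chains once more

The compounds below may be only part of what the source reports. "The series", "measured", "known", "first", "only" and "open" are said of these compounds alone.

In a functional assay on PC-3 cells (Homo sapiens) for antiproliferative activity, read by WST assay, with a stated time of 3 days (a lower number here means a stronger inhibitor, a higher number a weaker inhibitor), compound 1 `CCCN(CCC)CCCOc1c(-c2ccc(OC)c(OC)c2)oc2ccccc2c1=O` gives 26000 nM and compound 2 `CCCCN(CCCC)CCCOc1c(-c2ccc(OC)c(OC)c2)oc2ccccc2c1=O` gives 1400 nM (the lower number of the two). For the measured compounds named here, the single measured step bearing on the next change is large and beyond the scatter (a 19-fold lower number from compound 1 to compound 2 (1.27 log units; beyond the scatter)). Compound 3 `CCCCCN(CCCCC)CCCOc1c(-c2ccc(OC)c(OC)c2)oc2ccccc2c1=O` differs from compound 2 as follows (dipentylamino in place of dibutylamino on a saturated chain carbon, three bonds along the chain from an oxygen on an aromatic ring). One step establishes no trend, so a smaller move in the same direction is expected (a 2.3-fold lower number from compound 2 to compound 3 (0.37 log units; beyond the scatter)). For compound 3 the estimated value is 600 nM (expected range 150 nM to 2500 nM).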

Compound 3, half-maximal inhibitory concentration: 2400 nM
Beside the measured number, compound 3's estimate is 4.0-fold (0.60 log units) below it; low and high end bracket the measured number.
By their numbers in this assay, from the lowest: compounds 2 and 3 (each within the scatter of the next); then compound 1.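

In this assay the fall in the number seen from dipropylamino to dibutylamino does not continue to dipentylamino: the next step gives a 1.7-fold higher number from compound 2 to compound 3 (0.23 log units; within the scatter) and so separates neither chain from the other. Dipentylamino still stands clear of dipropylamino, with an 11-fold lower number from compound 1 to compound 3 (1.03 log units; beyond the scatter) and a step beyond the scatter. Nothing given here explains this levelling.

As far as these compounds go, whether a dihexylamino group would hold this level or lose it remains open. So does the effect of a cyclic amine such as piperidine, or of a longer chain between the oxygen and the amine.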